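From cyano to trifluoromethyl on the shared core

The source may report more compounds than this note shows. Statements on the series, on what has been measured and on what is new or still open speak of the compounds shown alone.

Compound 1 `NC(=S)NNc1ncnc2c1cnn2-c1ccc(F)cc1`: > 200000 nM
Compound 2 `N#Cc1ccc(-n2ncc3c(NNC(N)=S)ncnc32)cc1`: "nd(insoluble)" (no result reported)

In an ADME assay on cells (Peritoneal macrophage, Mus musculus, strain Swiss) for cytotoxicity, read by MTT assay, with a stated time of 48 h (on this read-out higher numbers stand for lower toxicity in this test and lower numbers for higher toxicity in this test), compound 2 has no number, only the entry "nd(insoluble)" (no result reported). Compound 1 gives > 200000 nM, which is a limit of the assay and not a number. Compound 3 `NC(=S)NNc1ncnc2c1cnn2-c1ccc(C(F)(F)F)cc1` is still unmeasured. The change trifluoromethyl in place of cyano on an aromatic carbon puts trifluoromethyl in place of cyano on an aromatic carbon, para to a large group. Among the compounds with values here, no measured step shows what such a change does, so the only guide is compound 1 with its limit of > 200000 nM, and no step beyond the scatter from that limit is expected in this assay. Compound 3 is expected at 180000 nM, within an estimated range of 60000 nM to 200000 nM.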

Compound 3, concentration lethal to 50% of the cells: > 200000 nM
Compound 3 ended at the assay's limit; the forecaster's own chance of this, stated with the estimate: 60%; middle value at least 1.1-fold (0.04 log units) from the limit.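

Compound 1 and compound 3 both give a limit of the assay and not a number, so no step between them can be read: the limit of > 200000 nM in this assay, at which 2 of the 3 values shown sit.

The compounds shown leave open whether trifluoromethyl in place of fluoro or cyano on an aromatic carbon changes the result in this assay.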